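The compounds below may be only part of what the source reports. "The series", "measured", "known", "first", "only" and "open" are said of these compounds alone.

Compound 1, with the structure `O=C1CC(Oc2ncccn2)CN1c1cnn2c1CN(C(=O)Nc1cc(F)c(F)c(F)c1)C(C1CC1)C2`, was tested in a toxicity assay on HepG2 2.2.15 cells (Homo sapiens) for cytotoxicity, read by CellTiter-Glo; on this read-out higher numbers stand for lower toxicity in this test and lower numbers for higher toxicity in this test. Compound 1 gives > 200000 nM, which is a limit of the assay rather than a measured number. So compound 1 stands at the top of the values shown, at the limit of > 200000 nM in this assay, at which 1 of the 3 values shown sits. Two close relatives are measured: compound 2, `O=C1NC(c2ccccc2)CN1c1cnn2c1CN(C(=O)Nc1cc(F)c(F)c(F)c1)C(C1CC1)C2`, gives 38500 nM in this assay, and compound 3, `O=C1CC(c2nccs2)CN1c1cnn2c1CN(C(=O)Nc1cc(F)c(F)c(F)c1)C(C1CC1)C2`, gives 115000 nM. The step of a 3.0-fold higher number from compound 2 to compound 3 (0.48 log units; beyond the scatter) is modest but beyond the scatter. The step of an at least 1.7-fold lower number from compound 1 to compound 3 (0.24 log units; that floor lies within the scatter) reaches only a floor, because compound 1 sits at the limit (the limit of > 200000 nM in this assay, at which 1 of the 3 values shown sits).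

Compound 4, `O=C1CC(c2ncccn2)CN1c1cnn2c1CN(C(=O)Nc1cc(F)c(F)c(F)c1)C(C1CC1)C2`, is not yet measured. It differs from compound 1 by pyrimidin-2-yl in place of (pyrimidin-2-yl)oxy on a saturated ring carbon. Among the compounds with values here, the one measured step that bears on this change is an at least 1.7-fold lower number from compound 1 to compound 3 (0.24 log units; that floor lies within the scatter), where a different aromatic ring also replaced the (pyrimidin-2-yl)oxy on the same saturated ring carbon and the number moved down by an amount whose floor lies within the scatter. A step of similar or smaller size is expected here, downward if anything, and possibly none beyond the scatter. Compound 4 is therefore estimated at 150000 nM in this assay, with a range from 60000 nM to 300000 nM. This estimate would mean an expected step of an at least 1.3-fold lower number from compound 1 to compound 4 (0.12 log units; that floor lies within the scatter).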

Compound 4, half-maximal cytotoxic concentration: > 200000 nM
Compound 4 ended at the assay's limit; the forecaster's own chance of this, stated with the estimate: 35%; at least 1.3-fold (0.12 log units) between middle value and limit.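

In this assay, the (pyrimidin-2-yl)oxy group on the saturated ring carbon can lose its oxygen and the result still stays at the top of the range: compound 4 gives > 200000 nM, which is a limit of the assay and not a number. The step between compound 1 and compound 4 cannot be read because neither compound gives a number, only the same limit: the limit of > 200000 nM in this assay, at which 2 of the 4 values shown sit.

Set against the other relatives, the new result gives an at least 1.7-fold higher number from compound 3 to compound 4 (0.24 log units; that floor lies within the scatter), so pyrimidin-2-yl and 1,3-thiazol-2-yl on this carbon cannot yet be told apart, and an at least 5.1-fold higher number from compound 2 to compound 4 (0.71 log units; beyond the scatter), a clearer gap that comes with the exchange of the whole 2-oxo-4-phenylimidazolidin-1-yl group on an aromatic carbon rather than a change at this position alone.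

From the compounds shown here alone, how far compound 1 and compound 4 lie past the limit remains open, so any effect of the oxygen in this test is still unknown. Also open, going by these compounds, is whether a group without an aromatic ring on the same saturated ring carbon, such as an amine or a carboxylic acid, would stay at the limit too.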